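Fluoro to ethoxy on the anilino ring

The source may hold more compounds than are shown below. What is called first, only, known or untested is meant among the compounds shown, and "the series" means these compounds.

compound 1 `O=C1C=C(Nc2ccccc2F)C(=O)c2c1nc1n2[C@H]2OC[C@@H](O)[C@H]2OC1`: 2080 nM
compound 2 `COc1ccccc1NC1=CC(=O)c2c(nc3n2[C@H]2OC[C@@H](O)[C@H]2OC3)C1=O`: 1670 nM

Among the compounds with values here, in a functional assay on MGC-803 cells (Homo sapiens) for inhibition, read by sulforhodamine B assay (on this read-out lower numbers stand for stronger inhibition and higher numbers for weaker inhibition), compound 1 gives 2080 nM, the higher of the two numbers so far; compound 2 gives 1670 nM, and the two values lie within the scatter of each other, so no order can be read from them. Compound 3 `CCOc1ccccc1NC1=CC(=O)c2nc3n(c2C1=O)[C@H]1OC[C@@H](O)[C@H]1OC3` has not been measured. The change from compound 1 is ethoxy in place of fluoro on an aromatic carbon. Since compound 2 with its methoxy sits within the scatter of compound 1, the step of a 1.2-fold lower number from compound 1 to compound 3 (0.06 log units; within the scatter) is expected to be small, in either direction or none beyond the scatter. Compound 3 is estimated at 1800 nM, in the range 800 nM to 4000 nM.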

Compound 3, half-maximal inhibitory concentration: 2450 nM
Beside the measured number, compound 3's estimate is 1.4-fold (0.13 log units) below it, within the range that was stated.
By their numbers in this assay, from the lowest: compounds 2, 1 and 3 (each within the scatter of the next).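

In this assay ethoxy in place of fluoro on an aromatic carbon gives a 1.2-fold higher number from compound 1 to compound 3 (0.07 log units; within the scatter) and so stays within the scatter. At this position, ortho to a large group, 2-ethoxyphenyl with its 3 heavy atoms and 1 hydrogen-bond acceptor therefore cannot be told apart from 2-fluorophenyl with its 1 heavy atom. Nothing at hand bears on why these two values lie so close.

On these data alone, whether an amine, a carboxylic acid or a longer alkoxy chain such as butoxy at this position would move the number beyond the scatter stays open.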